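Removing an Acetyl Group on Two Different Cores

A few compounds are considered here, and "the series" means these few. Any claim that something is new, unique, unknown or untested is made for them only; others in the source may bear on it.

Compound 1 `COc1ccc(C2=C(c3cc(OC)c(OC)c(OC)c3)C(=O)C(O)C2)cc1Cl` and compound 2 `COc1ccc(C2=C(c3cc(OC)c(OC)c(OC)c3)C(=O)C(OC(C)=O)C2)cc1Cl` share one core, while compound 3 `CC(=O)OC1C/C(=N/O)C(c2ccccc2)=C1c1ccccc1` is built on another. The difference between the two cores is not broken down here. In an ADME assay on HEp-2 cells (Homo sapiens) for cytotoxicity, read by MTT assay, with a stated time of 72 h (a higher number here means a weaker inhibitor, a lower number a stronger inhibitor), compound 1 gives < 1 ug/mL, a limit of the assay rather than a number. In this assay compound 2 likewise gives < 1 ug/mL, also a limit. Compound 3 in this assay gives > 100 ug/mL, again a limit, at the far end of the scale. The change from compound 2 to compound 1 is hydrogen in place of acetyl on an oxygen on a saturated carbon, and its step that the two limits leave unreadable from compound 2 to compound 1 stays unreadable, both values sitting at the limit of < 1 ug/mL in this assay, at which 2 of the 3 values shown sit. Compound 4 `O/N=C1/CC(O)C(c2ccccc2)=C1c1ccccc1`, not yet measured, carries the same change from compound 3: hydrogen in place of acetyl on an oxygen on a saturated carbon. The measured pair offers no readable size to go on. The expected step is a number no higher from compound 3 to compound 4 (the limit leaves the size open), kept small. In this assay compound 4 is therefore estimated at 100 ug/mL, between 30 ug/mL and 300 ug/mL.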

Compound 4, half-maximal inhibitory concentration: > 100 ug/mL
Compound 4 gave a limit, no number; the forecaster's own chance of this, stated with the estimate: 70%; the middle value sits exactly at the limit.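

Compound 3 and compound 4 both give a limit rather than a number, and the step between them cannot be read: the limit of > 100 ug/mL in this assay, at which 2 of the 4 values shown sit.

The compounds shown leave open how large the change from acetoxy to hydroxy is on either core.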